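The source may report more compounds than this note shows. Statements on the series, on what has been measured and on what is new or still open speak of the compounds shown alone.

Working notes on the sulfonyl series, read in an ADME assay on HCT-116 cells (Homo sapiens) for cytotoxicity, read by CellTiter-Glo, with a stated time of 72 h; on this read-out higher numbers stand for weaker inhibition and lower numbers for stronger inhibition. Compound 1 `CC1CCN(C2CCN(S(=O)(=O)c3ccccc3Br)CC2)CC1` gives > 5000 nM, which is a limit of the assay and not a number. Compound 2 `CC1CCN(C2CCN(S(=O)(=O)c3cncc(Br)c3)CC2)CC1` gives > 10000 nM, which is also a limit. Compound 2 therefore has no numerical position in the series, and neither measured compound yet offers a number to compare.

The next change leads to compound 3 `CC1CCN(C2CCN(S(=O)(=O)c3ccc(F)cc3F)CC2)CC1`: 2,4-difluorophenyl in place of 5-bromopyridin-3-yl on a sulfonyl sulfur. In words, this is 2,4-difluorophenyl in place of 5-bromopyridin-3-yl on a sulfonyl sulfur. Within the data shown here, the only measured step at this sulfonyl sulfur is a step that the two limits leave unreadable from compound 1 to compound 2. Its size cannot be read, so it gives no size to carry over to the new change. No step beyond the scatter can be argued from it, and none is expected in this assay. The expectation for compound 3 rests on compound 2 at > 10000 nM, a limit, and a further limit is the likely read-out. For compound 3 the estimate is 10000 nM, with an expected range from 5000 nM to 30000 nM. The estimated step is a number no higher from compound 2 to compound 3 (the limit leaves the size open).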

Compound 3, half-maximal inhibitory concentration: > 5000 nM
Compound 3 gave a limit, no number; the forecaster's own chance of this, stated with the estimate: 85%; the middle value lies beyond the limit too.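

In this assay compound 3 gives > 5000 nM, which is a limit of the assay, and the steps to compound 3 from compound 1 and from compound 2 cannot be read. The compounds shown leave open whether any group on the sulfonyl sulfur gives a numerical value in this assay, and how large any step would be.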